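The source may report more compounds than this note shows. Statements on the series, on what has been measured and on what is new or still open speak of the compounds shown alone.

Compound 1 `COc1ccc2oc(SCCC(=O)N3CCCC3)nc2c1` sets the scene for this small series. In an ADME assay on microsomes from liver (Mus musculus) for metabolic stability, read by LC-MS, using NADPH, with a stated time of 45 min, tested at 0.5 uM (on this read-out lower numbers stand for slow clearance and higher numbers for fast clearance), compound 1 gives 198 mL/min/g, which sits at the fast-clearance end of the read-out. Compound 2 `O=C(CCSc1nc(-c2ccccc2)co1)N1CCCC1` belongs to the same series, but for compound 2 this assay reports only "not determined" (no result reported), so no number is available. Compound 3 `O=C(CCSc1nc2cc(Cl)ccc2o1)NC1CCCC1` is the direct parent of the step followed here; for compound 3 this assay likewise reports "not determined" (no result reported), so compound 3 stands nowhere on the numbers shown and no second result without a number helps to place it. Compound 4 `CCN(CC)C(=O)CCSc1nc2cc(Cl)ccc2o1` differs from compound 3 in one place: diethylamino in place of cyclopentylamino on a carbonyl carbon. Among the measured compounds shown here, since no measured pair in the set changes one group at a time, no step size can be read from the data, and the only anchor is the fast clearance of compound 1. Within the usual scatter, compound 4 is expected to give 180 mL/min/g in this assay, in a range from 80 mL/min/g to 400 mL/min/g.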

Compound 4, intrinsic clearance in a liver preparation (reported as CLH), per the amount of preparation that the assay uses: 108 mL/min/g
Estimate against measurement, compound 4: 1.7-fold (0.22 log units) above; the range from low to high includes it.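

Among the compounds shown here, no step from compound 3 to compound 4 can be read in this assay, where compound 3 has no single number. The compounds shown leave open whether diethylamino in place of cyclopentylamino shifts clearance at all. Nothing shown offers an explanation for the value of compound 4.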